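Replacing ethoxycarbonyl with vinyl on compound 2

The source may hold more compounds than are shown below. What is called first, only, known or untested is meant among the compounds shown, and "the series" means these compounds.

In a functional assay on MCF7 cells (Homo sapiens) for inhibition, read by radiometric assay and XTT assay (on this read-out higher numbers stand for weaker inhibition and lower numbers for stronger inhibition), compound 1 `C/C=C/C(C)=C/[C@@]1(C)SC(O)=CC1=O` gives > 80 ug/mL, which is a limit and not a number. Compound 2 `CCCCCC[C@@]1(C)SC(=O)C=C1OCC(=O)OCC` reads 39.6 ug/mL and compound 3 `CCCCCCCC[C@@]1(C)SC(=O)C=C1OCC(=O)OCC` reads 35.3 ug/mL, so these two stand within the scatter of each other. Compound 4 `C=CCOC1=CC(=O)S[C@]1(C)CCCCCC` differs from compound 2 as follows: vinyl in place of ethoxycarbonyl on a saturated chain carbon bound to an oxygen on an unsaturated carbon. Going by the values given here, the only measured step, a 1.1-fold lower number from compound 2 to compound 3 (0.05 log units; within the scatter), lies on the saturated chain and not at this place, so it bears only indirectly. In this assay the expected change, a 1.0-fold higher number from compound 2 to compound 4 (0.00 log units; within the scatter), is estimated to stay within the scatter. For compound 4 the estimated value is 40 ug/mL, with an expected range of 18 ug/mL to 80 ug/mL.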

Compound 4, half-maximal inhibitory concentration: 9 ug/mL
Compound 4: the middle estimate sits 4.4-fold (0.65 log units) above what was measured; the whole stated range lies above it.
By their numbers in this assay, from the lowest: compound 4; then compounds 3 and 2 (each within the scatter of the next). At a limit, above all of these: compound 1.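

In this assay, the place on a saturated chain carbon bound to an oxygen on an unsaturated carbon proves sensitive to substitution: vinyl in place of ethoxycarbonyl gives a 4.4-fold lower number from compound 2 to compound 4 (0.64 log units; beyond the scatter). The chain change gave only a 1.1-fold lower number from compound 2 to compound 3 (0.05 log units; within the scatter), so this is the one step shown that lies beyond the scatter. No measurement shown accounts for this step.

Open, on these data alone, is how a propyl group or a free carboxylic acid would read at this place. Also open, as far as these compounds go, is whether allyl gives a similar step on the longer chain of compound 3.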